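From Methyl to Fluoro: an Estimate for Compound 4

This account rests on a few compounds, and the source may have more. Where it says the series, first, only, none or still open, it means among the compounds named here.

Compound 1 `COc1cc(-c2ncnn2-c2cccc(F)c2)cc(OC)c1OC` — > 10000 nM, a limit of the assay
Compound 2 `COc1cc(-n2ncnc2-c2ccc(C)cc2)cc(OC)c1OC` — 250 nM
Compound 3 `COc1cc(-c2ncnn2-c2cccc([N+](=O)[O-])c2)cc(OC)c1OC` — > 10000 nM, a limit of the assay

Within the data shown here, in a functional assay on HeLa cells (Homo sapiens) for antiproliferative activity, read by MTT assay, with a stated time of 72 h (on this read-out higher numbers stand for weaker inhibition and lower numbers for stronger inhibition), compound 2 gives the only number among the three measured compounds. Compound 1 sits at a limit of the assay, > 10000 nM. Compound 3 likewise sits at a limit, > 10000 nM. Among the measured compounds shown here, the one measured step, a step that the two limits leave unreadable from compound 1 to compound 3, therefore has no readable size, since two of the three values sit at the limit of > 10000 nM in this assay, at which 2 of the 3 values shown sit. Compound 4 `COc1cc(-n2ncnc2-c2ccc(F)cc2)cc(OC)c1OC` differs from compound 2 by fluoro in place of methyl on an aromatic carbon. For the measured compounds named here, no measured step covers this change on the ring attached to the shared core of compound 2, so the expected step of a 1.6-fold higher number from compound 2 to compound 4 (0.20 log units; within the scatter) lies within the usual scatter. The estimate for compound 4 is 400 nM, ranging from 150 nM to 1500 nM.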

Compound 4, half-maximal inhibitory concentration: > 10000 nM
Compound 4: no number, only a limit; the forecaster's own chance of this, stated with the estimate: 10%; at least 25-fold (1.39 log units) between middle value and limit.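

In this assay, among these compounds, the change from 4-methylphenyl to 4-fluorophenyl gives the first readable step at this position, an at least 40-fold higher number from compound 2 to compound 4 (1.60 log units; beyond the scatter) and so shows that one heavy atom on this ring can separate a measurable number from none. Compound 4 gives a limit and not a number: the limit of > 10000 nM in this assay, at which 3 of the 4 values shown sit. Among the compounds shown, methyl is thus the only group at this position with a number. As far as these compounds go, how a chloro or an ethyl would read here remains open. So does the true size of the step, which the limit leaves without an upper end.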